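Imide nitrogen substitution and azole chain swap in one series

This account rests on a few compounds, and the source may have more. Where it says the series, first, only, none or still open, it means among the compounds named here.

Compound 1 `Cn1cc(C2=C(c3nn(CCCn4cccc4)c4ncccc34)C(=O)NC2=O)c2ccccc21` and compound 2 `Cn1cc(C2=C(c3nn(CCCCn4ccnc4)c4ncccc34)C(=O)NC2=O)c2ccccc21` share a core that differs only in the chain-borne azole; the change between them is (1H-imidazol-1-yl)methyl in place of 1H-pyrrol-1-yl on a saturated chain carbon, three bonds along the chain from an aromatic nitrogen. In a functional assay on SMMC-7721 cells (Homo sapiens) for antiproliferative activity, read by MTT assay, with a stated time of 48 h (a higher number here means a weaker inhibitor, a lower number a stronger inhibitor), compound 1 reaches only the limit > 100000 nM, which is a limit of the assay and not a number. In this assay compound 2 gives 29200 nM. The step is an at least 3.4-fold lower number from compound 1 to compound 2 (0.53 log units; beyond the scatter).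

Compound 3 `Cn1cc(C2=C(c3nn(CCCn4cccc4)c4ncccc34)C(=O)N(c3ccccc3)C2=O)c2ccccc21` carries the same chain as compound 1 but differs in the core by phenyl in place of hydrogen on an amide-type nitrogen in a ring. In this assay compound 3 also sits at the limit > 100000 nM, again a limit and not a number. Between compound 1 and compound 3 the step is a step that the two limits leave unreadable from compound 1 to compound 3, because both sit at the limit of > 100000 nM in this assay, at which 2 of the 3 values shown sit.

Compound 4 `Cn1cc(C2=C(c3nn(CCCCn4ccnc4)c4ncccc34)C(=O)N(c3ccccc3)C2=O)c2ccccc21` is not yet measured. It stands to compound 3 as compound 2 stands to compound 1: the change is (1H-imidazol-1-yl)methyl in place of 1H-pyrrol-1-yl on a saturated chain carbon, three bonds along the chain from an aromatic nitrogen, the same kind of change, with the place described in the same words. Whether the phenyl-bearing core of compound 3 responds to it as the core of compound 1 did cannot be read, since compound 3 gives only a limit in this assay.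

Resting on the step from compound 1 to compound 2 an at least 3.4-fold lower number from compound 1 to compound 2 (0.53 log units; beyond the scatter) and on the limit for compound 3, compound 4 is expected to move by an at least 1.6-fold lower number from compound 3 to compound 4 (0.22 log units; that floor lies within the scatter). For compound 4 in this assay the estimated value is 60000 nM, with an expected range from 20000 nM to 150000 nM.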

Compound 4, half-maximal inhibitory concentration: 1760 nM
For compound 4 the middle estimate is 34-fold (1.53 log units) above the measured one; measured number below the stated range.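

In this assay, the change from 3-(1H-pyrrol-1-yl)propyl to 4-(1H-imidazol-1-yl)butyl, carried onto the core with phenyl on the amide-type nitrogen, gives an at least 56-fold lower number from compound 3 to compound 4 (1.75 log units; beyond the scatter), so the lower number seen on the core of compound 1 recurs on this second core. With the 4-(1H-imidazol-1-yl)butyl chain in place, phenyl in place of hydrogen on the amide-type nitrogen gives a 17-fold lower number from compound 2 to compound 4 (1.22 log units; beyond the scatter), whereas the matching step with the 3-(1H-pyrrol-1-yl)propyl chain cannot be read, as both of its ends are limits and not numbers: the limit of > 100000 nM in this assay, at which 2 of the 4 values shown sit. The direction of the chain change therefore holds on both cores shown, but these data do not show that its size carries over from one core to the other: the same change on two cores in this assay, an at least 3.4-fold lower number (0.53 log units; beyond the scatter) from compound 1 to compound 2 and an at least 56-fold lower number (1.75 log units; beyond the scatter) from compound 3 to compound 4; the limit leaves it open whether they differ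

The compounds shown change the ring and the chain length together, so they do not separate the imidazole ring from the extra chain carbon; a 4-(1H-pyrrol-1-yl)butyl or a 3-(1H-imidazol-1-yl)propyl chain would bear on that. Also open, on these data alone, is whether the phenyl step holds for another group on the amide-type nitrogen, such as benzyl or methyl, or for a chain ending in an amine.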